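Diaryl urea series: dichlorophenyl variant of compound 2

The compounds below may be only part of what the source reports. "The series", "measured", "known", "first", "only" and "open" are said of these compounds alone.

Two members of this series have been measured. Compound 1 `COc1cc2cc(Oc3ccc(NC(=O)Nc4cccc(C(F)(F)F)c4)cc3)c(C)nc2cc1OC` gives 9240 nM in a functional assay on 786-0 cells (Homo sapiens) for inhibition, read by sulforhodamine B assay, with a stated time of 48 h; a lower number here means a stronger inhibitor of growth, a higher number a weaker inhibitor of growth. Compound 2 `COc1cc2cc(Oc3ccc(NC(=O)Nc4ccc(Cl)c(C(F)(F)F)c4)cc3)c(C)nc2cc1OC` gives 4970 nM in this assay. Among the measured compounds shown here, the only step between measured compounds, a 1.9-fold lower number from compound 1 to compound 2 (0.27 log units; within the scatter), is chloro in place of hydrogen on an aromatic carbon. For the measured compounds named here, on the numbers so far compound 2 shows the lowest value of the two, yet its distance to compound 1 lies within the scatter, so no order between them can be claimed.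

Compound 3 `COc1cc2cc(Oc3ccc(NC(=O)Nc4ccc(Cl)c(Cl)c4)cc3)c(C)nc2cc1OC` is the next analogue. The change is chloro in place of trifluoromethyl on an aromatic carbon; in full, 4-chloro-3-(trifluoromethyl)phenyl becomes 3,4-dichlorophenyl. Going by the values given here, no measured step addresses the exchange of trifluoromethyl for chloro; the single step from compound 1 to compound 2 touched only the neighbouring position and stayed within the scatter. With no shown step to build on, the expectation is a step from compound 2 that does not exceed the scatter, written as a 1.1-fold higher number from compound 2 to compound 3 (0.04 log units; within the scatter). Compound 3 is therefore expected near 5500 nM, with the estimated range running from 2000 nM to 15000 nM.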

Compound 3, concentration for total growth inhibition: 17700 nM
Compound 3: middle estimate off by 3.2-fold (0.51 log units), on the low side; the measured number lies above the stated range.
By their numbers in this assay, from the lowest: compounds 2, 1 and 3 (each within the scatter of the next, the first and the last beyond it).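

In this assay the position holding trifluoromethyl is the one place in the series where a single exchange goes beyond the scatter: chloro in place of trifluoromethyl gives a 3.6-fold higher number from compound 2 to compound 3 (0.55 log units; beyond the scatter) as a modest step, while the earlier added chloro, a 1.9-fold lower number from compound 1 to compound 2 (0.27 log units; within the scatter), stayed within it. The other comparison, a 1.9-fold higher number from compound 1 to compound 3 (0.28 log units; within the scatter), is also within the scatter, so 3,4-dichlorophenyl and 3-(trifluoromethyl)phenyl cannot be ordered, and 4-chloro-3-(trifluoromethyl)phenyl stands apart only from 3,4-dichlorophenyl. Nothing in the available data accounts for the size of this step.

The compounds shown leave open whether the step belongs to the exchange of trifluoromethyl for chloro as such or only to a ring that also carries the second chloro, a question that would need the same exchange on a ring without that chloro. They also leave open how this position would read with a methoxy group, a nitrile, a dimethylamino group or a carboxylic acid in place of trifluoromethyl or chloro.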